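Trimethoxyphenyl triazole hydrazones: extending the sulfur substituent

The compounds below may be only part of what the source reports. "The series", "measured", "known", "first", "only" and "open" are said of these compounds alone.

Compound 1, `COc1cc(-c2nnc(SC)n2/N=C/c2ccccc2)cc(OC)c1OC`: > 200000 nM in a functional assay on HT-29 cells (Homo sapiens) for cytotoxicity, read by MTT assay, with a stated time of 48 h; a lower number here means a stronger inhibitor, a higher number a weaker inhibitor.
Compound 2, `COc1ccc(/C=N/n2c(SC)nnc2-c2cc(OC)c(OC)c(OC)c2)c(OC)c1`: 144000 nM in this assay.

In this assay compound 1 returns only a limit, > 200000 nM. In this assay compound 2 gives 144000 nM. Among the compounds with values here, the single measured step, an at least 1.3-fold lower number from compound 1 to compound 2 (0.14 log units; that floor lies within the scatter), rests on that limit (the limit of > 200000 nM in this assay, at which 1 of the 2 values shown sits), and its floor lies within the scatter, so it cannot be read as a real gain. Within the data shown here, compound 2 therefore holds the only number; the other value is a limit.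

Compound 3, `COc1ccc(/C=N/n2c(SCc3ccccc3)nnc2-c2cc(OC)c(OC)c(OC)c2)c(OC)c1`, differs from compound 2 by phenyl in place of hydrogen on a saturated chain carbon bound to a sulfur. Among the measured compounds shown here, no measured step touches this place: the one step recorded, an at least 1.3-fold lower number from compound 1 to compound 2 (0.14 log units; that floor lies within the scatter), concerns the carbon with a double bond to nitrogen and is itself at its floor within the scatter, so it offers no direction for the thioether change. For the measured compounds named here, with no precedent, the expected step for compound 3 is a 1.4-fold lower number from compound 2 to compound 3 (0.16 log units; within the scatter), that is, nothing beyond the scatter in this assay. Compound 3 is accordingly estimated at 100000 nM in this assay, with a range from 30000 nM to 300000 nM.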

Compound 3, half-maximal inhibitory concentration: > 200000 nM
Compound 3 ended at the assay's limit; the forecaster's own chance of this, stated with the estimate: 35%; middle value at least 2.0-fold (0.30 log units) away from the limit.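

Within the data shown here, the methylsulfanyl to benzylsulfanyl change gives the first reading at this place, on a saturated chain carbon bound to a sulfur, and it comes out as an at least 1.3-fold higher number from compound 2 to compound 3 (0.14 log units; that floor lies within the scatter). In this assay, as far as these compounds go, compound 3 returns only a limit, > 200000 nM, so the true size of the step stays unknown. The phenyl entering here therefore brings no visible gain over compound 2, and the series offers no measured direction at the sulfur substituent, with most of its values now at the top of the measurable range: the limit of > 200000 nM in this assay, at which 2 of the 3 values shown sit.

From the compounds shown here alone, whether an amine or a carboxylic acid at this place, in place of phenyl, would give a number clear of the limit remains open. Also open, going by these compounds, is how the benzylsulfanyl group behaves with phenyl rather than 2,4-dimethoxyphenyl on the carbon with a double bond to nitrogen, and with compound 1 and compound 3 both at the limit, the two changes cannot yet be compared in size.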